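Fluoro in Place of Nitro on a Thiosemicarbazone Aryl Ring

The source may hold more compounds than are shown below. What is called first, only, known or untested is meant among the compounds shown, and "the series" means these compounds.

Measured in a functional assay on MCF7 cells (Homo sapiens) for cytotoxicity, read by MTT assay, with a stated time of 48 h; on this read-out higher numbers stand for weaker inhibition and lower numbers for stronger inhibition:
Compound 1, `CC(=NNC(=S)Nc1cccc([N+](=O)[O-])c1)c1ccccn1`: 38 nM
Compound 2, `CC(=NNC(=S)Nc1cccc(F)c1)c1ccccn1`: 9 nM
Compound 3, `C/C(=N/NC(=S)Nc1ccc([N+](=O)[O-])cc1)c1ccccn1`: 52 nM

Compound 1 and compound 2 differ in a single place: fluoro in place of nitro on an aromatic carbon. This change produced a 4.2-fold lower number from compound 1 to compound 2 (0.63 log units; beyond the scatter). Compound 3 is built from the same atoms as compound 1, joined differently; the difference between the two cores is not broken down here, and their two values lie close together.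

Compound 4, `C/C(=N/NC(=S)Nc1ccc(F)cc1)c1ccccn1`, has not yet been measured in this assay. It differs from compound 3 by fluoro in place of nitro on an aromatic carbon. The surroundings are not identical: in going from compound 1 to compound 2 the group sits meta to a large group, while in going from compound 3 to compound 4 it sits para to a large group, so this is the same kind of change rather than the same change. Because a 4.2-fold lower number from compound 1 to compound 2 (0.63 log units; beyond the scatter), a step of similar direction is expected here, estimated as a 3.5-fold lower number from compound 3 to compound 4 (0.54 log units; beyond the scatter), with some widening of the range for the changed position. Compound 4 is therefore expected to give about 15 nM, estimated to fall between 6 nM and 40 nM.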

Compound 4, half-maximal inhibitory concentration: 1.2 nM
Beside the measured number, compound 4's estimate is 13-fold (1.10 log units) above it, outside the stated range (below it).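

Fluoro in place of nitro lowers the number on both cores in this assay, and the new step is a 43-fold lower number from compound 3 to compound 4 (1.64 log units; beyond the scatter). The direction of the change carries from one core to the other, but its size does not: the same change on two cores in this assay, a 4.2-fold lower number (0.63 log units; beyond the scatter) from compound 1 to compound 2 and a 43-fold lower number (1.64 log units; beyond the scatter) from compound 3 to compound 4, 10-fold (1.01 log units) apart, beyond the scatter of two such steps. A step measured on one core in this series therefore points the way on the other but gives no safe figure for how far, and these two pairs cannot show why the sizes differ, as they do not separate the place of the group on the ring from any other difference between the cores.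

The compounds shown leave open how a chloro group, an amine or a carboxylic acid in the same place would compare with fluoro and nitro on each core. They also leave open whether the larger or the smaller step would be repeated on a third core.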